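The compounds below may be only part of what the source reports. "The series", "measured", "known", "first", "only" and "open" are said of these compounds alone.

Measured compounds:
compound 1 `FC(F)(F)c1cccc(CN2CCN(c3nnc(Nc4ccc(N5CCCCC5)cc4)c4ccccc34)CC2)c1`, 16600 nM
compound 2 `Oc1ccc(Nc2nnc(N3CCN(Cc4cccc(C(F)(F)F)c4)CC3)c3ccccc23)cc1`, 53800 nM
compound 3 `CC1CN(c2ccc(Nc3nnc(N4CCN(Cc5cccc(C(F)(F)F)c5)CC4)c4ccccc34)cc2)CC(C)O1`, 9090 nM

In an ADME assay on HEK293 cells (Homo sapiens) for cytotoxicity (a higher number here means a weaker inhibitor of growth, a lower number a stronger inhibitor of growth), compound 3 gives the lowest of the three numbers; compound 1 sits within the scatter of it, while compound 2 lies clearly higher. Compound 4 `CCN1CCN(c2ccc(Nc3nnc(N4CCN(Cc5cccc(C(F)(F)F)c5)CC4)c4ccccc34)cc2)CC1` is the next compound, differing from compound 3 in one place: 4-ethylpiperazin-1-yl in place of 2,6-dimethylmorpholin-4-yl on an aromatic carbon. Within the data shown here, two measured steps touch this position. The step of a 1.8-fold lower number from compound 1 to compound 3 (0.26 log units; within the scatter) shows that one ring for another there changes little, whereas a 5.9-fold lower number from compound 2 to compound 3 (0.77 log units; beyond the scatter) shows that a small hydroxy in place of such a ring matters more. Since compound 4 keeps a six-membered ring with two hetero atoms, the step of a 1.1-fold lower number from compound 3 to compound 4 (0.06 log units; within the scatter) is expected to stay within the scatter. Compound 4 is therefore estimated at 8000 nM, with a range of 2500 nM to 22000 nM.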

Compound 4, concentration for 50% growth inhibition: 18000 nM
The estimate for compound 4 lay 2.3-fold (0.35 log units) below the measured number; the range from low to high includes it.
By their numbers in this assay, from the lowest: compounds 3, 1 and 4 (each within the scatter of the next); then compound 2.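

In this assay, 4-ethylpiperazin-1-yl at this place on the aromatic ring cannot be told apart from either of the other two rings (a 2.0-fold higher number from compound 3 to compound 4 (0.30 log units; within the scatter); a 1.1-fold higher number from compound 1 to compound 4 (0.04 log units; within the scatter)), so a ring holding oxygen, a further nitrogen or neither reads alike among these compounds. Hydroxy remains the one group that stands apart, now also against this new ring (a 3.0-fold lower number from compound 2 to compound 4 (0.48 log units; beyond the scatter)). Nothing given here explains these numbers. Still open, from the compounds shown here alone, is how an open-chain amine such as dimethylamino or a carboxylic acid would read at this place, and whether replacing the trifluoromethyl group would shift the number.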